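The source may report more compounds than this note shows. Statements on the series, on what has been measured and on what is new or still open speak of the compounds shown alone.

Compound 3 `CCN(CC)c1ncnc2c1ncn2Cc1ccccc1F` is the reference point for this step. In a functional assay on the whole organism with Rattus norvegicus as the target, in the maximal electroshock model (a lower number here means that less compound is needed, a higher number that more compound is needed for the effect), compound 3 gives 4.2 mg/kg, the lowest of the two plain numbers in the set; the nearest is compound 1 `CC(C)Nc1ncnc2c1ncn2Cc1ccccc1F`, which gives 5.8 mg/kg, and the step of a 1.4-fold lower number from compound 1 to compound 3 (0.14 log units; within the scatter) stays within the scatter, so no order between the two is claimed. For compound 2 `CC(C)(C)Nc1ncnc2c1ncn2Cc1ccccc1F` the value in this assay is a limit, > 50 mg/kg; this is the limit of > 50 mg/kg in this assay, at which 1 of the 3 values shown sits. The steps of an at least 8.6-fold higher number from compound 1 to compound 2 (0.93 log units; beyond the scatter) and an at least 11-fold lower number from compound 2 to compound 3 (1.07 log units; beyond the scatter) mark the (tert-butyl)amino analogue as the one clear outlier among the three.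

Compound 4 `CN(C=O)c1ncnc2c1ncn2Cc1ccccc1F` is obtained from compound 3 by formyl(methyl)amino in place of diethylamino on an aromatic carbon. Going by the values given here, no measured step exchanges an alkylamino group for formyl(methyl)amino, so the earlier steps bear on it only indirectly: they show that diethylamino and isopropylamino sit within the scatter of each other in this assay, and that one other substitution at this position pushed the value to a limit. A modest rise in dose is therefore expected, a 2.4-fold higher number from compound 3 to compound 4 (0.38 log units; beyond the scatter). Compound 4 is estimated at 10 mg/kg in this assay, spanning 3 mg/kg to 40 mg/kg.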

Compound 4, dose for half-maximal effect: 11 mg/kg
Estimate against measurement, compound 4: 1.1-fold (0.04 log units) below; low and high end bracket the measured number.
By their numbers in this assay, from the lowest: compounds 3, 1 and 4 (each within the scatter of the next, the first and the last beyond it). At a limit, above all of these: compound 2.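

Formyl(methyl)amino is the first group at this aromatic carbon to carry a carbonyl, and the position still gives a plain number: the step is a 2.6-fold higher number from compound 3 to compound 4 (0.42 log units; beyond the scatter), while against the isopropylamino analogue it is a 1.9-fold higher number from compound 1 to compound 4 (0.28 log units; within the scatter), so only the diethylamino analogue separates from the new group. Against the (tert-butyl)amino analogue the step is an at least 4.5-fold lower number from compound 2 to compound 4 (0.65 log units; beyond the scatter), which shows that a carbonyl-bearing group here stays well clear of the one outlier. Compound 2 remains the only compound at a limit, which is not a number: the limit of > 50 mg/kg in this assay, at which 1 of the 4 values shown sits.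

The compounds shown leave open whether the difference from compound 3 follows the carbonyl or the change in the alkyl groups on the nitrogen. Dimethylamino and acetyl(methyl)amino at this carbon would separate those two changes.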